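Methoxy at the fused benzene ring of compound 3

A few compounds are considered here, and "the series" means these few. Any claim that something is new, unique, unknown or untested is made for them only; others in the source may bear on it.

Three compounds have numbers in a functional assay on HEK293 cells (Homo sapiens) for inhibition, read by MTT assay, with a stated time of 48 h (a higher number here means a weaker inhibitor, a lower number a stronger inhibitor), so far. Compound 1 `COc1cc(C2=NOC(c3c[nH]c4ccccc34)C2)cc(OC)c1OC` gives 5000 nM in this assay. Compound 2 `Cc1[nH]c2ccccc2c1C1CC(c2ccncc2)=NO1` reaches only a limit of the assay, > 100000 nM, in this assay. Compound 3 `Clc1ccc(Cn2cc(C3CC(c4ccncc4)=NO3)c3ccccc32)cc1` gives 10200 nM in this assay; among the two numbers that are not limits, compound 3 stands highest, with compound 1 the nearest, and the gap between them lies beyond the usual scatter. The limit of compound 2 is noted as such: the limit of > 100000 nM in this assay, at which 1 of the 3 values shown sits.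

The next compound, compound 4 `COc1ccc2c(c1)c(C1CC(c3ccncc3)=NO1)cn2Cc1ccc(Cl)cc1`, differs from compound 3 in one place: methoxy in place of hydrogen on an aromatic carbon. Within the data shown here, no measured pair shows a comparable change, so the size of the step cannot be taken from the numbers. A step from compound 3 to compound 4 of no more than the scatter is expected, a 1.1-fold lower number from compound 3 to compound 4 (0.05 log units; within the scatter), with no clear direction. Compound 4 is estimated at 9000 nM in this assay, between 3000 nM and 30000 nM.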

Compound 4, half-maximal inhibitory concentration: 14200 nM
Compound 4: the middle estimate sits 1.6-fold (0.20 log units) below what was measured; the range from low to high includes it.
By their numbers in this assay, from the lowest: compound 1; then compounds 3 and 4 (each within the scatter of the next). At a limit, above all of these: compound 2.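

In this assay the series now has its first step in one place, with methoxy in place of hydrogen on an aromatic carbon giving a 1.4-fold higher number from compound 3 to compound 4 (0.14 log units; within the scatter) and so no change that can be told apart from repeat scatter. In this one pair, the carbon that is meta to a fused ring and para to a fused ring takes the added methoxy without a readable gain or loss. Nothing measured on these compounds gives a reason for the step.

One substituent at this carbon is only a single point: a fluorine, a hydroxyl or an amine there could move the number beyond the scatter or leave it in place. Also open, as far as these compounds go, is whether methoxy on the other carbons of that six-membered ring would read the same.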